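This account rests on a few compounds, and the source may have more. Where it says the series, first, only, none or still open, it means among the compounds named here.

In an ADME assay (liver) for metabolic stability, with Liver microsome (Rattus norvegicus) as the target, using microsomes and NADPH, with a stated time of 30 min, tested at 1 uM (on this read-out higher numbers stand for fast clearance and lower numbers for slow clearance), compound 3 `Nc1ccc(S(=O)(=O)N2CCN(c3ncc(C(O)(C(F)(F)F)C(F)(F)F)cc3-c3ccoc3)CC2)cn1` gives 57 mL.min-1.g-1, the highest number measured here. Compound 2 `Nc1ccc(S(=O)(=O)N2CCN(c3ncc(C(O)(C(F)(F)F)C(F)(F)F)cc3C3CC3)CC2)cn1` gives 27 mL.min-1.g-1. Compound 1 `COc1cc(C(O)(C(F)(F)F)C(F)(F)F)cnc1N1CCN(S(=O)(=O)c2ccc(N)nc2)CC1` is reported only as a limit, < 14 mL.min-1.g-1. Compound 4 `Nc1ccc(S(=O)(=O)N2CCN(c3ncc(C(O)(C(F)(F)F)C(F)(F)F)cc3-c3ccccc3O)CC2)cn1` differs from compound 3 at one place: 2-hydroxyphenyl in place of furan-3-yl on an aromatic carbon, with 2-hydroxyphenyl in place of furan-3-yl on an aromatic carbon. Three measured steps change the group at this same place: an at least 1.9-fold higher number from compound 1 to compound 2 (0.28 log units; that floor lies within the scatter), an at least 4.0-fold higher number from compound 1 to compound 3 (0.60 log units; beyond the scatter) and a 2.1-fold higher number from compound 2 to compound 3 (0.32 log units; beyond the scatter). None of them involves 2-hydroxyphenyl, so they give no direction for this change, and no step beyond the scatter is expected in this assay. The estimate is a 1.3-fold lower number from compound 3 to compound 4 (0.10 log units; within the scatter), an expected shift of small size. For compound 4, the expected value is 45 mL.min-1.g-1, with an estimated range from 20 mL.min-1.g-1 to 100 mL.min-1.g-1.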

Compound 4, intrinsic clearance in microsomes: 125 mL.min-1.g-1
Estimate against measurement, compound 4: 2.8-fold (0.44 log units) below; measured number outside the range, above it.
By their numbers in this assay, from the lowest: compound 2; then compound 3; then compound 4. At a limit, below all of these: compound 1.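

In this assay, 2-hydroxyphenyl at this position, ortho to a large group, gives the highest clearance number of the series, with a 2.2-fold higher number from compound 3 to compound 4 (0.34 log units; beyond the scatter) and a 4.6-fold higher number from compound 2 to compound 4 (0.67 log units; beyond the scatter), so furan-3-yl does not mark the top of the range here. Against methoxy the change gives an at least 8.9-fold higher number from compound 1 to compound 4 (0.95 log units; beyond the scatter). Compound 1 stands only at a limit, so that step is a floor: the limit of < 14 mL.min-1.g-1 in this assay, at which 1 of the 4 values shown sits.

The compounds shown leave open whether the rise follows the six-membered aromatic ring or its hydroxyl; phenyl or 2-methoxyphenyl at this place would separate the two. As far as these compounds go, how an amine or a carboxylic acid on that ring would read also stays open.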